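The source may report more compounds than this note shows. Statements on the series, on what has been measured and on what is new or still open speak of the compounds shown alone.

Measured compounds in a functional assay on MCF7 cells (Homo sapiens) for cytotoxicity, read by MTT assay, with a stated time of 72 h; a lower number here means a stronger inhibitor, a higher number a weaker inhibitor:
compound 1, `CN1CCN(Cc2nnc(-c3cc(S(N)(=O)=O)c(SCc4ccccc4)cc3Cl)o2)CC1` — 75000 nM
compound 2, `NC(=O)c1cn(Cc2nnc(-c3cc(S(N)(=O)=O)c(SCc4ccccc4)cc3Cl)o2)nn1` — 78000 nM
compound 3, `CC(C)(O)c1cn(Cc2nnc(-c3cc(S(N)(=O)=O)c(SCc4ccccc4)cc3Cl)o2)nn1` — 168000 nM

The three compounds share one core and differ only in the group carried on the saturated chain carbon bound to the aromatic carbon of the core. Compound 3 gives the highest number of the three in this assay. Its nearest neighbour is compound 2, with a 2.2-fold higher number from compound 2 to compound 3 (0.33 log units; beyond the scatter); the step of a 2.2-fold higher number from compound 1 to compound 3 (0.35 log units; beyond the scatter) is of the same size. Compound 1 and compound 2 lie within the scatter of each other, a 1.0-fold higher number from compound 1 to compound 2 (0.02 log units; within the scatter).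

Compound 4, `COc1ccc(-c2cn(Cc3nnc(-c4cc(S(N)(=O)=O)c(SCc5ccccc5)cc4Cl)o3)nn2)cc1`, is not yet measured. It differs from compound 3 in one place: 4-methoxyphenyl in place of 1-hydroxy-1-methylethyl on an aromatic carbon. For the measured compounds named here, the only measured step that touches the same aromatic carbon of the five-membered ring is the step from compound 2 to compound 3, in which a carbamoyl became a 1-hydroxy-1-methylethyl and the number rose modestly, a 2.2-fold higher number from compound 2 to compound 3 (0.33 log units; beyond the scatter). That single step gives no firm direction for a methoxyphenyl, and nothing measured carries an aromatic ring at this carbon. Compound 4 is therefore expected to stay in the range spanned by the three measured compounds, with a modest estimated step of a 1.7-fold lower number from compound 3 to compound 4 (0.23 log units; within the scatter) toward a somewhat lower number. The estimated value for compound 4 in this assay is 100000 nM, with a range from 40000 nM to 250000 nM.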

Compound 4, half-maximal inhibitory concentration: 1500000 nM
Estimate against measurement, compound 4: 15-fold (1.18 log units) below; the measured number lies above the stated range.
By their numbers in this assay, from the lowest: compounds 1 and 2 (each within the scatter of the next); then compound 3; then compound 4.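

In this assay, for the compounds shown here, the aromatic carbon of the five-membered ring with 3 nitrogen proves far less tolerant than the earlier compounds suggested: 4-methoxyphenyl in place of 1-hydroxy-1-methylethyl gives an 8.9-fold higher number from compound 3 to compound 4 (0.95 log units; beyond the scatter) in this series, and 4-methoxyphenyl in place of carbamoyl gives a 19-fold higher number from compound 2 to compound 4 (1.28 log units; beyond the scatter) on the same carbon. Both steps are larger than the one between the two earlier groups, a 2.2-fold higher number from compound 2 to compound 3 (0.33 log units; beyond the scatter) at this carbon, so the choice of group here can shift the number much further than that step alone showed. Compound 4 is the only one shown with a six-membered aromatic ring of carbon only at this carbon, and it is the weakest of the four inhibitors, but nothing in the data given explains why this change has so large an effect.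

The compounds shown leave open whether the aromatic ring itself or its methoxy group goes with the higher number, a question that a plain phenyl or a 4-hydroxyphenyl at this carbon would address. They also leave open whether an amine or a carboxylic acid on this carbon would give a number lower than those of compound 1 and compound 2.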